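Adding a Chlorine to the Fluorophenyl Ring of Compound 1

The source may report more compounds than this note shows. Statements on the series, on what has been measured and on what is new or still open speak of the compounds shown alone.

Compound 1 `CCOC(=O)C1=Cc2ccccc2OC1(OCc1cn(-c2ccc(F)cc2)nn1)C(F)(F)F` carries an ethyl ester and a trifluoromethyl group on its core, with a fluorophenyl-bearing triazole on the side chain. In a functional assay on DU-145 cells (Homo sapiens) for inhibition, read by MTT assay, with a stated time of 24 h (on this read-out lower numbers stand for stronger inhibition and higher numbers for weaker inhibition), compound 1 gives 8900 nM, the lowest of the two numbers measured here. Compound 2 `O=C(O)C1=Cc2ccccc2OC1(OCc1cc(-c2ccc([N+](=O)[O-])cc2)no1)C(F)(F)F` bears a free acid and a nitrophenyl-isoxazole side chain, and in this assay compound 2 gives 100000 nM. Compound 3 `O=C(O)C1=Cc2ccccc2OC1(OCc1cc(-c2ccc(F)cc2F)no1)C(F)(F)F` gives > 150000 nM in this assay, which is a limit of the assay and not a number. The step from compound 2 to compound 3, a 2,4-difluorophenyl in place of 4-nitrophenyl on an aromatic carbon, reads an at least 1.5-fold higher number from compound 2 to compound 3 (0.17 log units; that floor lies within the scatter).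

Compound 4 `CCOC(=O)C1=Cc2ccccc2OC1(OCc1cn(-c2ccc(F)c(Cl)c2)nn1)C(F)(F)F` differs from compound 1 by a single change: chloro in place of hydrogen on an aromatic carbon. Among the compounds with values here, no measured step here concerns adding a chloro to this ring, or any change at all on the triazole side chain of compound 1; the only measured step concerns a different side chain and a different aryl group. With nothing pointing either way, a step within the usual scatter is expected, so that in this assay the change from compound 1 to compound 4 is estimated at a 1.3-fold lower number from compound 1 to compound 4 (0.10 log units; within the scatter). Compound 4 is therefore expected to give about 7000 nM in this assay, between 2500 nM and 25000 nM.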

Compound 4, half-maximal inhibitory concentration: 21500 nM
Compound 4: the middle estimate sits 3.1-fold (0.49 log units) below what was measured, and the stated range covers the measured number.
By their numbers in this assay, from the lowest: compound 1; then compound 4; then compound 2. At a limit, above all of these: compound 3.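

Within the data shown here, the first measured change on the triazole side chain is a 2.4-fold higher number from compound 1 to compound 4 (0.38 log units; beyond the scatter), read in this assay. It shows that this position on the aryl ring, ortho to a fluoro group, responds to substitution: going from 4-fluorophenyl to 3-chloro-4-fluorophenyl weakens inhibition in these cells, by a modest step that lies beyond the usual scatter, something the earlier pair on the isoxazole side chain, which ends at a limit, could not show. Nothing measured here gives a reason for this step.

Going by these compounds, whether the weaker inhibition belongs to chlorine in particular or would follow any group on this carbon remains open, and a methyl, a methoxy or an amine at the same place would help separate those two readings. Also open, on these data alone, is whether the chloro would shift the number in the same direction on the isoxazole side chain, or with a free acid on the core in place of the ethyl ester.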